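This account rests on a few compounds, and the source may have more. Where it says the series, first, only, none or still open, it means among the compounds named here.

Measured compounds:

Compound 1 `Cc1ccc(S(=O)(=O)Oc2ccc3c(c2C)[C@H](Cn2cc(-c4ccccc4)nn2)[C@@]24CC(=O)[C@@](C)(CC[C@@H]32)C4)cc1` — in a functional assay on MCF7 cells (Homo sapiens) for cytotoxicity, read by MTT assay, with a stated time of 4 days (on this read-out higher numbers stand for weaker inhibition and lower numbers for stronger inhibition), compound 1 reaches only the limit > 20000 nM.
Compound 2 `C=C1C(=O)[C@]23C[C@@]1(O)CC[C@H]2c1ccc(O)c(C)c1[C@@H]3Cn1cc(-c2ccccc2)nn1` — in this assay compound 2 gives 1740 nM.
Compound 3 `Cc1ccc(S(=O)(=O)Oc2ccc3c(c2C)[C@H](Cn2cc(-c4ccccn4)nn2)[C@@]24CC(=O)[C@@](C)(CC[C@@H]32)C4)cc1` — in this assay compound 3 reaches only the limit > 20000 nM.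

Compound 1 and compound 3 share a core and differ only by pyridin-2-yl in place of phenyl on an aromatic carbon. The step that the two limits leave unreadable from compound 1 to compound 3 cannot be sized, because of the limit of > 20000 nM in this assay, at which 2 of the 3 values shown sit. Compound 2 has a different core; the difference between the two cores is not broken down here, and compound 2 is the only one of the three with a numerical result.

Compound 4 `C=C1C(=O)[C@]23C[C@@]1(O)CC[C@H]2c1ccc(O)c(C)c1[C@@H]3Cn1cc(-c2ccccn2)nn1` is built on the core of compound 2 and differs from it by pyridin-2-yl in place of phenyl on an aromatic carbon, the same change as between compound 1 and compound 3. Since that earlier step is unreadable, it offers no measured size to carry over; the expectation for compound 4 rests on compound 2 and its value 1740 nM, with a modest step of a 1.4-fold higher number from compound 2 to compound 4 (0.16 log units; within the scatter) assumed. Compound 4 is therefore estimated at 2500 nM, expected to lie between 800 nM and 9000 nM.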

Compound 4, half-maximal inhibitory concentration: 2240 nM
Estimate against measurement, compound 4: 1.1-fold (0.05 log units) above; the measured number falls inside the stated range.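

In this assay, putting pyridin-2-yl in place of phenyl on the core of compound 2 gives a 1.3-fold higher number from compound 2 to compound 4 (0.11 log units; within the scatter), so on this core the swap of a carbon for a ring nitrogen leaves the result within the usual scatter. On the core of compound 1 the same change cannot be sized, because compound 1 and compound 3 each reach only a limit and not a number: the limit of > 20000 nM in this assay, at which 2 of the 4 values shown sit. The series therefore offers one readable case of this change, which shows how it behaves on one core but does not show whether it would behave alike on the other.

The compounds shown carry only phenyl or pyridin-2-yl on the five-membered aromatic ring with 3 nitrogen, so it stays open how a simple amine, a carboxylic acid or a longer alkyl chain would fare at that place. From the compounds shown here alone, how much each part of the difference between the two cores counts also stays open.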